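This account rests on a few compounds, and the source may have more. Where it says the series, first, only, none or still open, it means among the compounds named here.

Working notes on the series. The shared core of compound 1 `Nc1ccccc1NC(=O)c1ccc(CSC(=S)N2CCN(C3CCCCC3)CC2)cc1` carries a cyclohexyl group on an amine nitrogen in a ring. In a functional assay on A-375 cells (Homo sapiens) for antiproliferative activity, read by CCK-8 assay, with a stated time of 72 h, tested at 8 uM (a lower number here means a weaker effect, a higher number a stronger effect of the compound at the concentration tested), compound 1 gives 89.9%, the highest of the three numbers measured. Compound 2 `Nc1ccccc1NC(=O)c1ccc(CSC(=S)N2CCc3ccc([N+](=O)[O-])cc32)cc1` gives 42% in this assay, a number below that of compound 1 by a gap beyond the scatter. Compound 3 `Nc1ccccc1NC(=O)c1ccc(CSC(=S)N2CCN(C(c3ccccc3)c3ccccc3)CC2)cc1` gives 8.4% in this assay, the furthest from compound 1, again beyond the scatter. For the measured compounds named here, no two measured compounds differ in one place only, so no single step can be read directly from them; what is seen is that the compound with a cyclohexyl group on the ring nitrogen stands high and the compound with a diphenylmethyl group on that nitrogen stands low.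

Compound 4 `Nc1ccccc1NC(=O)c1ccc(CSC(=S)N2CCN(Cc3cccnc3)CC2)cc1` is not yet measured. It differs from compound 1 as follows: (pyridin-3-yl)methyl in place of cyclohexyl on an amine nitrogen in a ring. The change puts an aromatic group bearing one ring nitrogen in place of the saturated ring. Going by the values given here, with no step in one place to lean on, the expectation is a decrease beyond the scatter, smaller than the gap between compound 1 and compound 3. The step of a number 29.9 percentage points lower from compound 1 to compound 4 (beyond the scatter) is the estimated move. Compound 4 is expected to give 60% in this assay, within 25% to 88%.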

Compound 4, a percentage reported as inhibition, at one concentration (the size of the read-out at that concentration, not a potency): 89.2%
Compound 4: the middle estimate sits 29.2 percentage points below what was measured, outside the stated range (above it).
By their numbers in this assay, from the lowest: compound 3; then compound 2; then compounds 4 and 1 (each within the scatter of the next).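

In this assay the one-place step reads a number 0.7 percentage points lower from compound 1 to compound 4 (within the scatter), with (pyridin-3-yl)methyl in place of cyclohexyl on an amine nitrogen in a ring. At this position, therefore, a six-membered non-aromatic ring of carbon only and a six-membered aromatic ring with 1 hetero atom, which brings 1 hydrogen-bond acceptor, give read-outs within the scatter of each other, so the high number of compound 1 does not depend on the cyclohexyl group as such. Nothing available on these compounds accounts for this result.

The compounds shown leave open whether the ring nitrogen of compound 4 plays any part in this number, which a benzyl group at the same position would test, and whether its location in the ring matters, which a (pyridin-4-yl)methyl group would test. The read-out is also the size of the effect at a single concentration and not a potency, so compound 1 and compound 4 remain unseparated only at that concentration.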